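Benzyl to hydrogen on the oxygen of compound 2

The source may hold more compounds than are shown below. What is called first, only, known or untested is meant among the compounds shown, and "the series" means these compounds.

Two compounds of the series have numbers in an assay on isolated protein for inhibition of proto-oncogene tyrosine-protein kinase receptor Ret (Homo sapiens), read by radiometric assay and 33P incorporation, in the presence of a further agent that is not named here; a lower number here means a stronger inhibitor, a higher number a weaker inhibitor. Compound 1 `CC(C)n1nc(-c2ccon2)c2c(N)ncnc21` gives 213 nM in this assay. Compound 2 `CC(C)n1nc(/C=N/OCc2ccccc2)c2c(N)ncnc21` gives 8330 nM in this assay, the highest of the two numbers; its nearest neighbour is compound 1, and the gap between them is beyond the scatter. Among the compounds with values here, no single-change pair of measured compounds is available, so no measured step can guide the next change.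

Compound 3 `CC(C)n1nc(/C=N/O)c2c(N)ncnc21` differs from compound 2 by hydrogen in place of benzyl on an oxygen whose other neighbours are a double-bonded nitrogen. With no measured step of this kind in hand, the expectation for compound 3 is a modest move toward lower numbers, of size a 2.8-fold lower number from compound 2 to compound 3 (0.44 log units; beyond the scatter), though a result within the scatter of compound 2 would not surprise. Compound 3 is estimated at 3000 nM in this assay, within a range from 800 nM to 12000 nM.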

Compound 3, half-maximal inhibitory concentration: 4900 nM
Compound 3: middle estimate off by 1.6-fold (0.21 log units), on the low side, and the stated range covers the measured number.
By their numbers in this assay, from the lowest: compound 1; then compounds 3 and 2 (each within the scatter of the next).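

In this assay, hydrogen in place of benzyl on the oxygen gives a 1.7-fold lower number from compound 2 to compound 3 (0.23 log units; within the scatter), so the number does not separate these two groups at this position. The group on the aromatic carbon makes the larger difference: the group of 3 heavy atoms in compound 3, in place of the five-membered aromatic ring in compound 1, gives a 23-fold higher number from compound 1 to compound 3 (1.36 log units; beyond the scatter). No supporting evidence bears on either step, so neither can be explained here.

Going by these compounds, it remains open whether a methyl group, a longer chain or a chain ending in an amine on the same oxygen would stay within the scatter of compound 3. On these data alone, it is also open whether a phenyl ring on the aromatic carbon would give a number nearer to that of compound 1 or of compound 3.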